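The compounds below may be only part of what the source reports. "The series", "measured", "known", "first", "only" and "open" are said of these compounds alone.

Measured compounds in the series:
compound 1 `CC1(C)[C@H]2CC[C@]1(C)N(Cc1cn(-c3ccccc3Br)nn1)C(=O)C2`: 500 nM
compound 2 `CC1(C)[C@H]2CC[C@]1(C)N(Cc1cn(-c3ccccc3C#N)nn1)C(=O)C2`: 260 nM
compound 3 `CC1(C)[C@H]2CC[C@]1(C)N(Cc1cn(-c3ccccc3F)nn1)C(=O)C2`: 300 nM

In a functional assay on SGC-7901 cells (Homo sapiens) for inhibition, read by MTT assay, with a stated time of 24 h (on this read-out lower numbers stand for stronger inhibition and higher numbers for weaker inhibition), compound 1 gives 500 nM, which is the top number of the three, but the separation is not real: a 1.7-fold lower number from compound 1 to compound 3 (0.22 log units; within the scatter) and a 1.9-fold lower number from compound 1 to compound 2 (0.28 log units; within the scatter), so the three compounds cannot be told apart on this read-out. Likewise a 1.2-fold higher number from compound 2 to compound 3 (0.06 log units; within the scatter).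

Compound 4 `CC1(C)[C@H]2CC[C@]1(C)N(Cc1cn(-c3ccccc3O)nn1)C(=O)C2` is the next member. It differs from compound 1 as follows: hydroxy in place of bromo on an aromatic carbon. The measured steps that bear on this are those in which the bromo group of compound 1 is exchanged for another group at the same aromatic carbon, namely cyano in place of bromo and fluoro in place of bromo, and both stayed within the scatter. Within the data shown here, no measured step introduces a hydroxy group, so the closest guide is the observation that this position has so far tolerated three different substituents without a shift beyond the scatter. The step of a 1.3-fold lower number from compound 1 to compound 4 (0.10 log units; within the scatter) is therefore expected to be small, with no movement beyond the scatter in either direction. On this basis compound 4 is expected to give 400 nM, with a likely range from 150 nM to 1200 nM.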

Compound 4, half-maximal inhibitory concentration: 410 nM
For compound 4 the middle estimate is 1.0-fold (0.01 log units) below the measured one; measured number inside the range.
By their numbers in this assay, from the lowest: compounds 2, 3, 4 and 1 (each within the scatter of the next).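

In this assay the step of a 1.2-fold lower number from compound 1 to compound 4 (0.09 log units; within the scatter) extends the tolerance at this aromatic carbon, ortho to a large group, to a substituent with 1 hydrogen-bond donor and 1 hydrogen-bond acceptor, whereas bromo has neither. The other two steps agree, since a 1.4-fold higher number from compound 3 to compound 4 (0.14 log units; within the scatter) and a 1.6-fold higher number from compound 2 to compound 4 (0.20 log units; within the scatter) also leave hydroxy unresolved from the earlier groups, so bromo, cyano, fluoro and hydroxy cannot be told apart at this carbon on this read-out. No measurement is available that would account for this flat result.

The compounds shown leave open whether this tolerance extends to an amine, a carboxylic acid, a methoxy group or a longer alkyl chain at the same carbon, any of which could test it beyond the four single-atom or small groups seen so far. They also leave open whether the same exchanges would behave alike at another carbon of the aromatic ring, or on a core other than the shared core of compound 1.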